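The source may report more compounds than this note shows. Statements on the series, on what has been measured and on what is new or still open speak of the compounds shown alone.

Among the compounds with values here, compound 1 `CC1=CC[C@H](C(C)(C)NC(=S)N/N=C/c2ccccc2O)CC1` gives 900 nM in a functional assay on PC-3 cells (Homo sapiens) for inhibition, read by sulforhodamine B assay, with a stated time of 48 h (a higher number here means a weaker inhibitor of growth, a lower number a stronger inhibitor of growth), the lowest of the three numbers so far. Compound 2 `CC1=CC[C@H](C(C)(C)NC(=S)N/N=C/c2ccccc2[N+](=O)[O-])CC1` gives 6400 nM in this assay, and compound 3 `CC1=CC[C@H](C(C)(C)NC(=S)N/N=C/c2cccc([N+](=O)[O-])c2)CC1` gives 88000 nM. Within the data shown here, the single measured one-place step, a 7.1-fold higher number from compound 1 to compound 2 (0.85 log units; beyond the scatter), shows that exchanging the hydroxy group on the aromatic ring for another group moved the number up. Compound 4 `CC1=CC[C@H](C(C)(C)NC(=S)N/N=C/c2cccs2)CC1` carries thiophen-2-yl in place of 2-hydroxyphenyl on a carbon with a double bond to nitrogen. Among the measured compounds shown here, no measured step covers a thiophen-2-yl group; the step from compound 1 to compound 2 is the only one bearing on removal of the hydroxy group, and it was modest yet beyond the scatter. A higher number is therefore expected for compound 4, as a 4.4-fold higher number from compound 1 to compound 4 (0.65 log units; beyond the scatter). The estimate for compound 4 is 4000 nM, within 1200 nM to 15000 nM.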

Compound 4, concentration for total growth inhibition: 62800 nM
For compound 4 the middle estimate is 16-fold (1.20 log units) below the measured one; the whole stated range lies below it.
By their numbers in this assay, from the lowest: compound 1; then compound 2; then compounds 4 and 3 (each within the scatter of the next).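

Exchanging 2-hydroxyphenyl for thiophen-2-yl on a carbon with a double bond to nitrogen is a large step (a 70-fold higher number from compound 1 to compound 4 (1.84 log units; beyond the scatter)), whereas the earlier exchange of hydroxy for nitro was modest (a 7.1-fold higher number from compound 1 to compound 2 (0.85 log units; beyond the scatter)). This position therefore does not accept every aromatic group, and the thiophen-2-yl group does not keep the number of compound 1.

This change removes the hydroxy group and the six-membered ring together, so a plain phenyl or a furan-2-yl group would be needed to separate the two. Nothing measured here explains the loss.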